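A few compounds are considered here, and "the series" means these few. Any claim that something is new, unique, unknown or untested is made for them only; others in the source may bear on it.

Measured so far in an assay on cells for antagonist activity at P2X purinoceptor 2 (Homo sapiens), read by fluorescence and calcium flux, with a stated time of 30 min; a higher number here means a weaker inhibitor, a lower number a stronger inhibitor:
- compound 1, `O=C(Nc1cc(C(F)(F)F)cc(C(F)(F)F)c1)c1ccc(Cl)cc1O`: > 10000 nM, a limit of the assay rather than a number
- compound 2, `O=C(Nc1cccc(C(F)(F)F)c1)c1cc(Cl)ccc1O`: > 10000 nM, again a limit rather than a number
- compound 3, `O=C(Nc1cc([N+](=O)[O-])cc(C(F)(F)F)c1)c1cc(Cl)ccc1O`: > 10000 nM, again a limit rather than a number

Compound 2 thus stands at the assay limit in this assay, and it does not stand alone there: the limit of > 10000 nM in this assay, at which 3 of the 3 values shown sit. Within the measured set the only single-point step, nitro in place of hydrogen on an aromatic carbon, is a step that the two limits leave unreadable from compound 2 to compound 3, so no direction or size can be read from it. Compound 1 adds nothing readable either, as its value is also a limit.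

Compound 4 is `O=C(Nc1cccc(Cl)c1)c1cc(Cl)ccc1O`. It differs from compound 2 in one place: chloro in place of trifluoromethyl on an aromatic carbon. Among the compounds with values here, no measured step concerns this exchange, and the measured compounds provide no reference point that is a number rather than a limit. The expectation for compound 4 therefore rests on the run of limits alone, and compound 4 is expected to remain at or near the limit, with a step that the limit leaves unreadable from compound 2 to compound 4 as the expected step. The estimate for compound 4 in this assay is 20000 nM, with a range from 5000 nM to 80000 nM.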

Compound 4, half-maximal inhibitory concentration: > 10000 nM
Compound 4 was reported as a limit (the forecaster's own chance of this, stated with the estimate: 80%); the middle value is on the limit's open side.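

In this assay compound 4 gives > 10000 nM, a limit rather than a number. Compound 2 is also a limit, so chloro in place of trifluoromethyl gives no readable step between compound 2 and compound 4. The series stands at one limit: the limit of > 10000 nM in this assay, at which 4 of the 4 values shown sit.

The compounds shown leave open which change to the shared core, if any, would give a numerical inhibitor value.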